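The source may hold more compounds than are shown below. What is called first, only, known or untested is meant among the compounds shown, and "the series" means these compounds.

Three compounds built on one shared core were tested in a functional assay on MDA-MB-231 cells (Homo sapiens) for antiproliferative activity, read by MTT assay, with a stated time of 48 h; a lower number here means a stronger inhibitor, a higher number a weaker inhibitor. Compound 1 `CCOC(=O)CN(Cc1ccccc1)c1nc(NCc2ccccc2)ncc1[N+](=O)[O-]` gives 82400 nM in this assay. Compound 2 `CCOC(=O)CN(Cc1ccccc1)c1nc(NCc2cccc(OC)c2)ncc1[N+](=O)[O-]` gives 80700 nM in this assay. Compound 3 `CCOC(=O)CNc1ncc([N+](=O)[O-])c(N(CC(=O)OCC)Cc2ccccc2)n1` gives 92500 nM in this assay. Compound 3 has the highest of the three numbers, yet its nearest neighbour, compound 1, and its furthest, compound 2, both lie within the scatter of it, so the three cannot be ranked.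

Compound 4 `CCOC(=O)CN(Cc1ccccc1)c1nc(Nc2cccc(OC)c2)ncc1[N+](=O)[O-]` differs from compound 3 by 3-methoxyphenyl in place of (ethoxycarbonyl)methyl on a nitrogen on an aromatic ring. Among the measured compounds shown here, no measured step exchanges these two groups on this nitrogen, so the expectation rests on the closest comparisons. The step of a 1.1-fold higher number from compound 1 to compound 3 (0.05 log units; within the scatter) and the step of a 1.1-fold higher number from compound 2 to compound 3 (0.06 log units; within the scatter) each traded an aromatic ring for an ethoxycarbonyl group on the saturated chain carbon bound to the ring nitrogen, and both stayed within the scatter. The step of a 1.0-fold lower number from compound 1 to compound 2 (0.01 log units; within the scatter) added the same methoxy group that compound 4 carries, also within the scatter. Compound 4 is therefore expected to show a 1.2-fold lower number from compound 3 to compound 4 (0.09 log units; within the scatter), a change not beyond the scatter. The estimated number for compound 4 in this assay is 75000 nM, with a range from 25000 nM to 200000 nM.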

Compound 4, half-maximal inhibitory concentration: 47200 nM
Estimate against measurement, compound 4: 1.6-fold (0.20 log units) above; the range from low to high includes it.
By their numbers in this assay, from the lowest: compounds 4, 2, 1 and 3 (each within the scatter of the next).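

Among the compounds shown here, compound 4 is the only one of the four compounds whose nitrogen on an aromatic ring carries an aromatic ring directly, where the others have a saturated chain carbon at that point. In this assay, 3-methoxyphenyl gives a 2.0-fold lower number from compound 3 to compound 4 (0.29 log units; within the scatter) when it replaces (ethoxycarbonyl)methyl, a 1.7-fold lower number from compound 2 to compound 4 (0.23 log units; within the scatter) when it replaces 3-methoxybenzyl, and a 1.7-fold lower number from compound 1 to compound 4 (0.24 log units; within the scatter) when it replaces benzyl. All three steps stay within the scatter, so this nitrogen has now carried an ester chain, two benzyl-type groups and a directly bound aromatic ring without any clear separation in the readout, and no available data offer an explanation for these numbers.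

The compounds shown leave open what plain phenyl would give on this nitrogen, so the methoxy group on the directly bound ring cannot be judged on its own. They also leave open whether a longer chain such as 2-phenylethyl on this nitrogen, or a carboxylic acid in place of the ethyl ester, would produce a step beyond the scatter.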